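Swapping allyl for 2-carboxyethenyl in a cytotoxicity series

A few compounds are considered here, and "the series" means these few. Any claim that something is new, unique, unknown or untested is made for them only; others in the source may bear on it.

Before a compound goes further, it helps to know how much of it living cells can tolerate. In an ADME assay on MT2 cells (Homo sapiens) for cytotoxicity, read by XTT assay, with a stated time of 4 days (a lower number here means that less compound is tolerated, a higher number that more compound is tolerated), compound 1 `Cc1cc(/C=C/C(=O)O)cc(C)c1Oc1ccc([N+](=O)[O-])c(Nc2ccc(C#N)cc2)n1` gives 34800 nM. Compound 2 `C=CCc1cc(C)c(Oc2ccc(N)c(Nc3ccc(C#N)cc3)n2)c(C)c1` gives 14000 nM, the lower of the two numbers, and its gap from compound 1 lies beyond the usual scatter of repeat measurements. These two compounds differ in more than one place, so the gap cannot be pinned on any single group.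

Compound 3 `Cc1cc(/C=C/C(=O)O)cc(C)c1Oc1ccc(N)c(Nc2ccc(C#N)cc2)n1` matches compound 2 except for one change: 2-carboxyethenyl in place of allyl on an aromatic carbon. For the measured compounds named here, no measured pair of compounds isolates this change, so any forecast is tentative. The best available guide is compound 1, which also carries 2-carboxyethenyl and gives 34800 nM. On that basis, the estimated step is a modest rise a 2.1-fold higher number from compound 2 to compound 3 (0.33 log units; beyond the scatter), which would mean that more compound is tolerated. For compound 3, the estimated value in this assay is 30000 nM, with an expected range from 12000 nM to 80000 nM.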

Compound 3, half-maximal cytotoxic concentration: 15700 nM
The estimate for compound 3 lay 1.9-fold (0.28 log units) above the measured number; low and high end bracket the measured number.
By their numbers in this assay, from the lowest: compounds 2 and 3 (each within the scatter of the next); then compound 1.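

In this assay, 2-carboxyethenyl in place of allyl on this aromatic carbon gives a 1.1-fold higher number from compound 2 to compound 3 (0.05 log units; within the scatter), so this assay cannot tell the two groups apart at this position, even though the entering group carries a hydrogen-bond donor and a hydrogen-bond acceptor that allyl lacks. For the compounds shown here, the change elsewhere on the core, amino in place of nitro on an aromatic carbon, gives a 2.2-fold lower number from compound 1 to compound 3 (0.35 log units; beyond the scatter), so of the two differences between compound 1 and compound 2, only this one shows a step beyond the scatter when taken alone. No measurement here explains either result.

Going by these compounds, what remains open is how far this tolerance at the position extends: a saturated propanoic acid chain, a longer chain or a basic amine in the same place could behave differently from the two groups seen so far. It is also unknown whether the step from nitro to amino would have the same size with allyl in place of 2-carboxyethenyl, a question that a nitro compound carrying allyl would answer.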